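Cytotoxicity notes on a nitrobenzamide benzoxazole pair

A few compounds are considered here, and "the series" means these few. Any claim that something is new, unique, unknown or untested is made for them only; others in the source may bear on it.

Compound 1 `O=C(Nc1cc(-c2nc3ccccc3o2)ccc1F)c1cc([N+](=O)[O-])ccc1Cl`: > 25000 nM in an ADME assay on HepG2 cells (Homo sapiens) for cytotoxicity, with a stated time of 72 h (a lower number here means that less compound is needed, a higher number that more compound is needed for the effect), a limit.
Compound 2 `O=C(Nc1cccc(-c2nc3ccccc3o2)c1)c1cc([N+](=O)[O-])ccc1Cl`: > 25000 nM in this assay, a limit.

Compound 2 stands only at a limit of this assay. Among the compounds with values here, the sole measured step, a step that the two limits leave unreadable from compound 1 to compound 2, cannot be read because both values sit at the limit of > 25000 nM in this assay, at which 2 of the 2 values shown sit. Compound 3 `COc1ccc(-c2nc3ccccc3o2)cc1NC(=O)c1cc([N+](=O)[O-])ccc1Cl` differs from compound 2 by methoxy in place of hydrogen on an aromatic carbon. Within the data shown here, no measured step bears on this change, so the expectation rests on the two limits alone: for compound 3 the expected step is a number no higher from compound 2 to compound 3 (the limit leaves the size open), none beyond the scatter. Compound 3 is estimated at 25000 nM, between 8000 nM and 50000 nM, most probably again only a limit in this assay.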

Compound 3, half-maximal effective concentration: > 25000 nM
Compound 3: only a limit was reported; the forecaster's own chance of this, stated with the estimate: 80%; the middle value sits exactly at the limit.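

No step among compound 1, compound 2 and compound 3 can be read, because all three values are limits: the limit of > 25000 nM in this assay, at which 3 of the 3 values shown sit.

From the compounds shown here alone, whether fluoro, hydrogen or methoxy on this aromatic carbon makes any difference in this assay stays open.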